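The source may report more compounds than this note shows. Statements on the series, on what has been measured and on what is new or still open speak of the compounds shown alone.

Of the compounds shown here, two have so far been measured in a physicochemical assay for acid dissociation. Compound 1 (`CN1CC[C@H]2CCC[C@@H](OC(=O)c3ccccc3)[C@H]2C1`) gives 9.05 and compound 2 (`CN1CC[C@H]2CCC[C@@H](OC(=O)c3ccc(Cl)cc3)[C@@H]2C1`) gives 8.75. These two numbers lie within the usual scatter of each other, so compound 2 cannot be separated from compound 1 on this evidence.

Compound 3 (`CN1CC[C@H]2CCC[C@@H](OC(=O)c3ccc(Cl)cc3)[C@H]2C1`) has not yet been measured. Set against compound 2, it shows this difference: the two compounds have the same atoms and bonds and differ only in configuration as drawn: 1 of 3 stereo elements differ; a stereocentre at a saturated ring carbon is drawn S in compound 2 and R in compound 3. Nothing leaves and nothing enters, and a stereocentre at a saturated ring carbon is drawn S in compound 2 and R in compound 3.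

Going by the values given here, no measured pair yet shows what a change of configuration alone does in this assay. The expectation therefore rests on the narrow band set by compound 1 at 9.05 and compound 2 at 8.75. A small upward move that stays within the scatter is expected, an estimated step of a number 0.15 log units higher from compound 2 to compound 3 (within the scatter). For compound 3 the estimated value is 8.9, with an expected range of 8.6 to 9.2.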

Compound 3, acid dissociation constant: 8.9
The estimate for compound 3 equals the measured number at the digits printed, and the stated range covers the measured number.
By their numbers in this assay, from the lowest: compounds 2, 3 and 1 (each within the scatter of the next).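

In this assay, going by these compounds alone, the step of a number 0.15 log units higher from compound 2 to compound 3 (within the scatter) gives the first reading of a change in configuration alone, and it shows that reversing this saturated ring carbon from S to R leaves no difference that can be told from the scatter. This pair isolates that one stereocentre, which the earlier comparison of compound 1 with compound 2 could not do: the fact that compounds 2 and 3 differ only in the configuration as drawn. Within the data shown here, compound 3 also supplies the first single-place reading for the aromatic substituent, where chloro in place of hydrogen on an aromatic carbon gives a number 0.15 log units lower from compound 1 to compound 3 (within the scatter), so this change too stays unresolved in this assay.

Going by these compounds, each of these readings rests on one pair, and the other stereo elements, which compound 2 and compound 3 share, remain untested on their own. On these data alone, it also remains open whether a nitrile or an amine in place of the chloro would give a step beyond the scatter in this assay.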